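A few compounds are considered here, and "the series" means these few. Any claim that something is new, unique, unknown or untested is made for them only; others in the source may bear on it.

Compounds measured in a functional assay on NCI-H1975 cells (Homo sapiens) for antiproliferative activity, read by MTT assay, with a stated time of 72 h (on this read-out higher numbers stand for weaker inhibition and lower numbers for stronger inhibition), so far:
Compound 1, `COc1cc2ncnc(Nc3ccc(F)c(Cl)c3)c2cc1OCCCCC(=O)Nc1ccc(S(N)(=O)=O)cc1`: 35600 nM
Compound 2, `COc1cc2ncnc(Nc3cccc(Cl)c3)c2cc1OCCCCC(=O)Nc1ccc(S(N)(=O)=O)cc1`: 33200 nM
Compound 3, `COc1cc2ncnc(Nc3cccc(Cl)c3F)c2cc1OCCCCC(=O)Nc1ccc(S(N)(=O)=O)cc1`: 6930 nM

Compound 2 stands second highest of these three numbers. Compound 1 lies nearest, and a 1.1-fold lower number from compound 1 to compound 2 (0.03 log units; within the scatter) is within the scatter, so no order between compounds 1 and 2 can be read. Compound 3 lies furthest, and a 4.8-fold lower number from compound 2 to compound 3 (0.68 log units; beyond the scatter) is a modest step beyond the scatter.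

Compound 4, `COc1cc2ncnc(Nc3ccc(OC(F)(F)F)cc3)c2cc1OCCCCC(=O)Nc1ccc(S(N)(=O)=O)cc1`, has not been measured. It differs from compound 2 in one place: 4-(trifluoromethoxy)phenyl in place of 3-chlorophenyl on a nitrogen on an aromatic ring. All measured steps concern fluoro and chloro on the phenyl that sits on a nitrogen on an aromatic ring: a 1.1-fold lower number from compound 1 to compound 2 (0.03 log units; within the scatter), within the scatter, a 5.1-fold lower number from compound 1 to compound 3 (0.71 log units; beyond the scatter) and a 4.8-fold lower number from compound 2 to compound 3 (0.68 log units; beyond the scatter), both modest. Among the compounds with values here, none of them exchanges that phenyl for a 4-(trifluoromethoxy)phenyl, so they show only that changes at this position have so far moved the number between not at all and modestly. The step in this assay is therefore expected to be small, possibly none beyond the scatter, with the direction uncertain. Compound 4 is expected to give about 30000 nM in this assay, estimated between 8000 nM and 100000 nM. This corresponds to an expected step of a 1.1-fold lower number from compound 2 to compound 4 (0.04 log units; within the scatter).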

Compound 4, half-maximal inhibitory concentration: 8770 nM
Estimate against measurement, compound 4: 3.4-fold (0.53 log units) above; the range from low to high includes it.
By their numbers in this assay, from the lowest: compounds 3 and 4 (each within the scatter of the next); then compounds 2 and 1 (each within the scatter of the next).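

In this assay, within the data shown here, the earlier steps only moved fluoro and chloro around the phenyl on this nitrogen, and among them only the 3-chloro-2-fluorophenyl of compound 3 gave a clearly lower number. The result shows that a differently substituted ring, 4-(trifluoromethoxy)phenyl, also lowers the number modestly, both against the 3-chlorophenyl (a 3.8-fold lower number from compound 2 to compound 4 (0.58 log units; beyond the scatter)) and against the 3-chloro-4-fluorophenyl (a 4.1-fold lower number from compound 1 to compound 4 (0.61 log units; beyond the scatter)), while no order can be read against compound 3 (a 1.3-fold higher number from compound 3 to compound 4 (0.10 log units; within the scatter)). So two quite different groups at this place give numbers that cannot be told apart, and this place accepts more than halogen changes, though all four numbers remain high and nothing measured here explains the steps.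

From the compounds shown here alone, whether the trifluoromethoxy group itself carries the step stays open, as a plain phenyl or a 4-methoxyphenyl on this nitrogen would be needed to compare with compound 4. Also open, going by these compounds, is how a phenyl bearing an amine or a carboxylic acid would behave here, and whether a longer chain to the sulfonamide-bearing ring would shift these numbers.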